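Dropping a methoxy from the aminothiazole ketone series

The compounds below may be only part of what the source reports. "The series", "measured", "known", "first", "only" and "open" are said of these compounds alone.

Measured compounds:
`COc1ccc(C(=O)c2sc(Nc3ccccc3)nc2N)cc1OC` compound 1: > 10000 nM
`COc1cc(C(=O)c2sc(Nc3ccc(C)cc3)nc2N)cc(OC)c1OC` compound 2: 15 nM
`COc1ccc(Nc2nc(N)c(C(=O)c3cc(OC)c(OC)c(OC)c3)s2)cc1` compound 3: 2200 nM

Compound 1 gives only a limit of the assay in a functional assay on FM3A cells (Mus musculus) for antiproliferative activity, read by cell counting, with a stated time of 2 days (on this read-out lower numbers stand for stronger inhibition and higher numbers for weaker inhibition), namely > 10000 nM. Compound 2 gives 15 nM in this assay, and compound 3 gives 2200 nM. Compound 3 therefore stands highest of the two numbers shown, with compound 2 nearest at a 150-fold higher number from compound 2 to compound 3 (2.17 log units; beyond the scatter).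

The piece follows the step to compound 4, `COc1ccc(Nc2nc(N)c(C(=O)c3ccc(OC)c(OC)c3)s2)cc1`, which differs from compound 3 in one place: hydrogen in place of methoxy on an aromatic carbon. Going by the values given here, no measured step shows this change directly; the one measured step, a 150-fold higher number from compound 2 to compound 3 (2.17 log units; beyond the scatter), concerns a different position. Compound 1 does lack the same methoxy that compound 4 lacks, yet it differs from compound 4 elsewhere, so it speaks to the change only loosely. Among the compounds with values here, since the number of compound 3 is already high, and the only compound without that methoxy sits at the limit (the limit of > 10000 nM in this assay, at which 1 of the 3 values shown sits), the number for compound 4 is expected to rise by a 3.6-fold higher number from compound 3 to compound 4 (0.56 log units; beyond the scatter). Compound 4 is estimated at 8000 nM, with a range from 2000 nM to 30000 nM, and a fair chance that this assay reports only a limit.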

Compound 4, half-maximal inhibitory concentration: 71 nM
Estimate against measurement, compound 4: 110-fold (2.05 log units) above; measured number below the stated range.
By their numbers in this assay, from the lowest: compound 2; then compound 4; then compound 3. At a limit, above all of these: compound 1.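

Taking this methoxy away from compound 3 does not cost activity in this assay; it gains it, with a 31-fold lower number from compound 3 to compound 4 (1.49 log units; beyond the scatter), so a low number in this series does not depend on keeping all three methoxy groups on the ketone side. Compound 1, which also carries hydrogen at this position, gives no number but a limit: the limit of > 10000 nM in this assay, at which 1 of the 4 values shown sits. Hydrogen here is therefore compatible with a low number, and the methoxy that compound 4 has in the other place, absent from compound 1, accounts for an at least 140-fold lower number from compound 1 to compound 4 (2.14 log units; beyond the scatter).

The compounds shown leave open whether the same removal would help when the methyl of compound 2 stands in that other place. They also leave open whether a hydroxyl, a fluorine or an ethoxy at this position would behave like hydrogen or like methoxy.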